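Ring Nitrogen Substituent Change in a Trifluoromethyl Chromene Series

The source may hold more compounds than are shown below. What is called first, only, known or untested is meant among the compounds shown, and "the series" means these compounds.

Measured compounds:
compound 1 `CCOC(=O)C1=Cc2ccccc2OC1(OCc1cn(CC(=O)Nc2cccc(F)c2)nn1)C(F)(F)F`: > 150000 nM
compound 2 `CCOC(=O)C1=Cc2ccccc2OC1(OCc1cc(-c2ccc(Br)cc2)no1)C(F)(F)F`: > 150000 nM
compound 3 `CCOC(=O)C1=Cc2ccccc2OC1(OCc1cc(-c2cccc(C(F)(F)F)c2)no1)C(F)(F)F`: 22100 nM

In a functional assay on MCF7 cells (Homo sapiens) for inhibition, read by MTT assay, with a stated time of 24 h (on this read-out higher numbers stand for weaker inhibition and lower numbers for stronger inhibition), compound 1 gives only a limit, > 150000 nM, which is a limit of the assay and not a number. Compound 2 likewise sits at a limit, > 150000 nM. Going by the values given here, compound 3 gives 22100 nM; the step of an at least 6.7-fold lower number from compound 2 to compound 3 (0.83 log units; beyond the scatter) is the only measured step here, and it concerns the isoxazole aryl group, not the position changed now. Compound 4 `CCOC(=O)C1=Cc2ccccc2OC1(OCc1cn(-c2cccc(OC)c2)nn1)C(F)(F)F` differs from compound 1 in 3-methoxyphenyl in place of ((3-fluorophenyl)carbamoyl)methyl on an aromatic nitrogen. Among the compounds with values here, no measured step bears on this change, and compound 1 is pinned only by the limit of > 150000 nM in this assay, at which 2 of the 3 values shown sit. Compound 4 is therefore expected to stay near the limit, with the step of an at least 1.2-fold lower number from compound 1 to compound 4 (0.09 log units; that floor lies within the scatter) expected to be small. The estimate for compound 4 is 120000 nM, ranging from 30000 nM to 300000 nM.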

Compound 4, half-maximal inhibitory concentration: > 150000 nM
Compound 4 ended at the assay's limit (the forecaster's own chance of this, stated with the estimate: 60%); middle value at least 1.2-fold (0.09 log units) away from the limit.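

No step can be read between compound 1 and compound 4, as each rests on a limit and not a number: the limit of > 150000 nM in this assay, at which 3 of the 4 values shown sit.

Still open, going by these compounds, is whether 3-methoxyphenyl in place of ((3-fluorophenyl)carbamoyl)methyl on an aromatic nitrogen changes inhibition at all.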